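The source may report more compounds than this note shows. Statements on the series, on what has been measured and on what is new or still open speak of the compounds shown alone.

Measured compounds:
- compound 1 `COc1cc(C2=NN(C(C)=O)C(c3c(Cl)cccc3Cl)O2)cc(OC)c1OC`: -1.4%
- compound 2 `COc1cc(C2=NN(C(C)=O)C(c3cc(OC)c(OC)c(OC)c3)O2)cc(OC)c1OC`: -1.8%
- compound 3 `COc1cc(C(=O)N/N=C/c2ccc(F)cc2)cc(OC)c1OC`: 50.9%

These three compounds were tested in a functional assay on BGC-823 cells (Homo sapiens) for antiproliferative activity, read by MTT assay, tested at 1 uM; on this read-out higher numbers stand for a stronger effect at the one concentration tested and lower numbers for a weaker effect. On these numbers compound 1 gives -1.4%, which is the second highest of the three, but its nearest neighbour, compound 2 with -1.8%, lies within the usual scatter of such measurements, so the two cannot be told apart. Compound 3, which has a different core, gives 50.9%, far beyond the scatter above compound 1.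

Compound 4 `COc1cc(C2=NN(C(C)=O)C(c3ccccc3F)O2)cc(OC)c1OC` shares the core of compound 1 and differs from it in one place:

2-fluorophenyl in place of 2,6-dichlorophenyl on a saturated ring carbon

For the measured compounds named here, no step between two measured compounds with this kind of change is available, so there is nothing to scale an expectation from. With compound 1 and compound 2 both near zero in this assay, and compound 2 carrying a quite different group at the same place, the step from compound 1 to compound 4 is expected to be small, with no change beyond the scatter, as a number 3.4 percentage points higher from compound 1 to compound 4 (within the scatter) states. Compound 4 is therefore estimated at 2%, within a range from -10% to 18%.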

Compound 4, a percentage reported as inhibition, at one concentration (the size of the read-out at that concentration, not a potency): 29.6%
Estimate against measurement, compound 4: 27.6 percentage points below; the measured number lies above the stated range.
By their numbers in this assay, from the lowest: compounds 2 and 1 (each within the scatter of the next); then compound 4; then compound 3.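

In this assay, the group on this saturated ring carbon clearly matters: 2-fluorophenyl in place of 2,6-dichlorophenyl gives a number 31 percentage points higher from compound 1 to compound 4 (beyond the scatter) at the one concentration tested. The printed values of compound 1 and compound 2 could not be told apart despite their quite different groups here, so the position had seemed unresponsive, whereas compound 4 shows that the same core can give a clear effect with the right group in this place. Nothing measured here explains the step.

From the compounds shown here alone, this single change removes two chlorines and adds one fluorine, so it remains open which part of the swap counts, and a plain phenyl group would help to separate them. Going by these compounds, how an amine or a carboxylic acid on this phenyl ring would behave also remains open.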